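The compounds below may be only part of what the source reports. "The series", "measured", "known", "first", "only" and "open" are said of these compounds alone.

Measured so far in an assay on isolated protein for inhibition of ubiquitin carboxyl-terminal hydrolase 7 (Homo sapiens), with stated times of 30 min and 2 h; on this read-out higher numbers stand for weaker inhibition and lower numbers for stronger inhibition:

Compound 1 `Cn1nc2c(=O)n(CC3(O)CCN(Cc4ccc(-c5ccco5)cc4Cl)CC3)cnc2c1-c1ccc(CO)cc1` — 42.5 nM
Compound 2 `CC(C)NCc1ccc(-c2c3ncn(CC4(O)CCN(Cc5ccc(-c6ccco6)cc5Cl)CC4)c(=O)c3nn2C)cc1` — 29.1 nM

Compound 2 has the lower of the two numbers in this assay, but its distance from compound 1, a 1.5-fold lower number from compound 1 to compound 2 (0.16 log units; within the scatter), lies within the scatter, so the two compounds cannot be told apart and no order between them is claimed.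

Compound 3 `Cn1nc2c(=O)n(CC3(O)CCN(Cc4ccc(-c5ccco5)cc4Cl)CC3)cnc2c1-c1ccc(CNC=O)cc1` has not been measured in this assay. It differs from compound 2 at one place: formyl in place of isopropyl on an amine nitrogen.

Going by the values given here, the only measured step that touches this position is a 1.5-fold lower number from compound 1 to compound 2 (0.16 log units; within the scatter), where a hydroxy on the saturated chain carbon was exchanged for the isopropylamino group and the number stayed within the scatter. Among the compounds with values here, no measured pair shows an amine nitrogen carrying a formyl in place of an alkyl, so the move to formylamino has no direct precedent. Within the data shown here, with the one relevant step flat, the expectation for this assay is a step of a 1.5-fold higher number from compound 2 to compound 3 (0.19 log units; within the scatter), that is, none that would clearly exceed the scatter, with a slight lean toward a higher number.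

Compound 3 is therefore estimated at 45 nM in this assay, with a range from 15 nM to 140 nM.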

Compound 3, half-maximal inhibitory concentration: 20.9 nM
Beside the measured number, compound 3's estimate is 2.2-fold (0.33 log units) above it; the measured number falls inside the stated range.
By their numbers in this assay, from the lowest: compounds 3, 2 and 1 (each within the scatter of the next, the first and the last beyond it).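

In this assay, the amine nitrogen on the saturated chain carbon takes formyl in place of isopropyl with a 1.4-fold lower number from compound 2 to compound 3 (0.14 log units; within the scatter), so the two groups cannot be told apart at this nitrogen. Going by these compounds alone, the comparison with hydroxy gives a 2.0-fold lower number from compound 1 to compound 3 (0.31 log units; beyond the scatter), the first modest step beyond the scatter: formylamino gives stronger inhibition than hydroxy at this place, whereas isopropylamino, with a 1.5-fold lower number from compound 1 to compound 2 (0.16 log units; within the scatter), does not separate from hydroxy. No measurement at hand bears on why these steps have the size they show.

Still open, as far as these compounds go, is whether the free primary amine, an acetyl or a methanesulfonyl on the same nitrogen, or a carboxylic acid in place of the whole amine group, would keep the number near those of compound 2 and compound 3 or move it clearly away from them. Also open, from the compounds shown here alone, is whether the modest separation from hydroxy persists with other groups on the shared core, since all three compounds differ only at this one position.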